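The source may report more compounds than this note shows. Statements on the series, on what has been measured and on what is new or still open speak of the compounds shown alone.

Compound 1, `COc1ccc(Cl)cc1COc1ccccc1C(=O)Nc1cccnc1`: 670 nM
Compound 2, `COCCOc1ccc(Cl)cc1COc1ccccc1C(=O)Nc1cccnc1`: 11600 nM

In an assay on lysate for inhibition of phosphatidylcholine:ceramide cholinephosphotransferase 2 (Homo sapiens), read by HPLC, with stated times of 30 min and 2 h (a higher number here means a weaker inhibitor, a lower number a stronger inhibitor), compound 1 gives 670 nM, while compound 2 gives 11600 nM. Compound 2 thus stands highest of the two numbers shown; its only neighbour is compound 1, and the step of a 17-fold higher number from compound 1 to compound 2 (1.24 log units; beyond the scatter) came with methoxymethyl in place of hydrogen on a saturated chain carbon bound to an oxygen on an aromatic ring.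

Compound 3, `COCCCOc1ccc(Cl)cc1COc1ccccc1C(=O)Nc1cccnc1`, carries the change (methoxymethyl in place of methoxy on a saturated chain carbon, two bonds along the chain from an oxygen on an aromatic ring). For the measured compounds named here, the single measured step that bears on it is a 17-fold higher number from compound 1 to compound 2 (1.24 log units; beyond the scatter), which lengthened the same chain and was large. Whether a further lengthening continues in that direction cannot be read from two compounds; a modest step in this assay, or none beyond the scatter, seems the most plausible outcome. Compound 3 is therefore expected to show a 1.1-fold higher number from compound 2 to compound 3 (0.05 log units; within the scatter), giving an estimated 13000 nM with a range of 4000 nM to 40000 nM.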

Compound 3, half-maximal inhibitory concentration: 4100 nM
For compound 3 the middle estimate is 3.2-fold (0.50 log units) above the measured one; the measured number falls inside the stated range.
By their numbers in this assay, from the lowest: compound 1; then compound 3; then compound 2.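

In this assay, the response at this position proves not to follow chain length in one direction: the change from 2-methoxyethoxy to 3-methoxypropoxy gives a 2.8-fold lower number from compound 2 to compound 3 (0.45 log units; beyond the scatter), recovering part of the loss seen with the shorter chain. The recovery is incomplete, since the 3-methoxypropoxy chain, set against the methoxy of the core of compound 1, still gives a 6.1-fold higher number from compound 1 to compound 3 (0.79 log units; beyond the scatter), so among these three compounds the parent methoxy keeps the lowest number and compound 2 stands against any steady rise with length. No measurement at hand explains why the longer chain fares better than the shorter one.

On these data alone, whether a 4-methoxybutoxy chain would extend this fall or reverse it remains open. So does the outcome for a plain propoxy chain or for a chain ending in an amine or a carboxylic acid.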